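Cytotoxicity notes on the hexanoic acid amide series

The compounds below may be only part of what the source reports. "The series", "measured", "known", "first", "only" and "open" are said of these compounds alone.

Compound 2 `CC(C)N(Cc1cccc(OCCCCCC(=O)O)c1)C(=O)c1ccc(-c2ccc3c(c2)OCCO3)cc1` stands only at a limit in an ADME assay on BJ cells (Homo sapiens) for cytotoxicity, read by CellTiter-Glo and resazurin assay, with a stated time of 72 h; on this read-out lower numbers stand for an effect already at smaller amounts and higher numbers for an effect only at larger amounts of compound. In this assay compound 2 gives the limit > 21900 nM. Compound 1 `CC(C)N(Cc1cccc(OCCCCCC(=O)O)c1)C(=O)c1ccc(-c2ccoc2)cc1` likewise gives only a limit, > 26000 nM. The step that the two limits leave unreadable from compound 1 to compound 2 therefore cannot be read. Compound 3 `COc1ccc(F)c(-c2ccc(C(=O)N(Cc3cccc(OCCCCCC(=O)O)c3)C(C)C)cc2)c1` carries 2-fluoro-5-methoxyphenyl in place of 2,3-dihydro-1,4-benzodioxin-6-yl on an aromatic carbon. Among the compounds with values here, no measured step bears on this change with a readable size, since both neighbours sit at limits (the limit of > 21900 nM in this assay, at which 1 of the 2 values shown sits, and (the limit of > 26000 nM in this assay, at which 1 of the 2 values shown sits)). Compound 3 is therefore expected to remain at a limit as well, with no step beyond the scatter in this assay, the expected step being a step that the limit leaves unreadable from compound 2 to compound 3. The estimate for compound 3 in this assay is 30000 nM, ranging from 10000 nM to 100000 nM.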

Compound 3, half-maximal effective concentration: > 26000 nM
Compound 3: a limit, no number; the forecaster's own chance of this, stated with the estimate: 80%; the middle value is on the limit's open side.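

Within the data shown here, compound 3, like compound 1 and compound 2, stands only at a limit in this assay, so no step among them can be read. The compounds shown leave open whether exchanging the group on the aromatic carbon changes cytotoxicity at all.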